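The source may report more compounds than this note shows. Statements on the series, on what has been measured and on what is new or still open speak of the compounds shown alone.

Of the compounds shown here, two have been measured so far in a functional assay on LoVo cells (Homo sapiens) for cytotoxicity, read by MTT assay; on this read-out lower numbers stand for stronger inhibition and higher numbers for weaker inhibition. Compound 1 (`Oc1ccc(CN(Cc2cccc(C(F)(F)F)c2)Cc2ccc(O)c3ncccc23)c2cccnc12`) gives 94 nM and compound 2 (`Oc1ccc(CN(Cc2cccs2)Cc2ccc(O)c3ncccc23)c2cccnc12`) gives 40 nM as the lower of the two numbers. Compound 3 (`O=C(O)C1CCC(CN(Cc2ccc(O)c3ncccc23)Cc2ccc(O)c3ncccc23)CC1`) keeps the shared core and changes one group, with 4-carboxycyclohexyl in place of thiophen-2-yl on a saturated chain carbon bound to an amine nitrogen. For the measured compounds named here, the only measured step at this place is modest (a 2.4-fold lower number from compound 1 to compound 2 (0.37 log units; beyond the scatter)). Both groups in that step hold an aromatic ring, whereas 4-carboxycyclohexyl holds a non-aromatic ring, so the step is only a weak guide to the new group. Compound 2 with 40 nM sits at the low end of what has been seen, so a move to a higher number is expected, somewhat larger than the measured step and with wide uncertainty. The estimated change is an upward one (a 3.8-fold higher number from compound 2 to compound 3 (0.57 log units; beyond the scatter)). For compound 3 the estimate is 150 nM with an expected range from 40 nM to 600 nM in this assay.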

Compound 3, half-maximal inhibitory concentration: 422 nM
Compound 3: middle estimate off by 2.8-fold (0.45 log units), on the low side, and the stated range covers the measured number.
By their numbers in this assay, from the lowest: compound 2; then compound 1; then compound 3.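

In this assay, the place on a saturated chain carbon bound to an amine nitrogen now shows a much wider span of numbers than the two aromatic groups alone had shown. Putting 4-carboxycyclohexyl in place of thiophen-2-yl gives an 11-fold higher number from compound 2 to compound 3 (1.02 log units; beyond the scatter) and counts as a large change, while the same swap for 3-(trifluoromethyl)phenyl gives a 4.5-fold higher number from compound 1 to compound 3 (0.65 log units; beyond the scatter) and counts as a modest one, so compound 3 ends with the highest number of the three and the weakest inhibition here. No measurement is available to explain this rise.

Compound 3 brings in two differences at once, the loss of the aromatic ring and the arrival of a carboxylic acid, and the compounds shown cannot tell which of them matters for the higher number. A plain cyclohexyl group would test the ring without the acid, and a phenyl ring carrying a carboxylic acid would test the acid on an aromatic ring.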